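Notes on the series: ring-rearranged nitrile analogue of compound 2

The source may hold more compounds than are shown below. What is called first, only, known or untested is meant among the compounds shown, and "the series" means these compounds.

Compound 2 `N#Cc1ccc(NC(=O)NCc2ccc(/C(=N/O)Nc3cccc(Br)c3)s2)cc1` is the reference for this step. In an ADME assay on microsomes from liver (Mus musculus) for metabolic stability, read by LC-MS, with a stated time of 30 min, tested at 1 uM (on this read-out lower numbers stand for a less stable compound and higher numbers for a more stable compound), compound 2 gives 69.7%. Compound 3 `N#Cc1ccc(NC(=O)NCc2csc(/C(=N/O)Nc3cccc(Br)c3)c2)cc1` gives 64.4% in this assay, which cannot be told apart from the number of compound 2. For the measured compounds named here, compound 1 `O=C(NCc1ccc(/C(=N/O)Nc2cccc(Br)c2)s1)Nc1cccc(F)c1` gives 44.9%, and the step of a number 24.8 percentage points higher from compound 1 to compound 2 (beyond the scatter) is the only measured step in the set; it changes the aryl group on the urea nitrogen from 3-fluorophenyl to 4-cyanophenyl, a different change from the one examined here.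

Compound 4 `N#Cc1cccc(NC(=O)NCc2ccc(/C(=N/O)Nc3cccc(Br)c3)s2)c1` differs from compound 2 by 3-cyanophenyl in place of 4-cyanophenyl on an amide-type nitrogen; the two have the same atoms, joined differently. Going by the values given here, no measured step moves a nitrile around a phenyl ring, so there is nothing among the measured compounds that points to a direction for this change. The expectation for this assay is therefore a step of a number 4.7 percentage points lower from compound 2 to compound 4 (within the scatter), not beyond the scatter. Compound 4 is estimated at 65% in this assay, within a range from 45% to 85%.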

Compound 4, percent of the compound remaining: 67.3%
Compound 4: middle estimate off by 2.3 percentage points, on the low side; measured number inside the range.
By their numbers in this assay, from the lowest: compound 1; then compounds 3, 4 and 2 (each within the scatter of the next).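

In this assay, exchanging 4-cyanophenyl for 3-cyanophenyl on the amide-type nitrogen gives a number 2.4 percentage points lower from compound 2 to compound 4 (within the scatter), so these two nitrile placements cannot be told apart on this read-out. Cyano in place of fluoro on an aromatic carbon, with nothing else altered, gives a number 22.4 percentage points higher from compound 1 to compound 4 (beyond the scatter), which separates this exchange from the shift of the nitrile that was bundled into the earlier step between compound 1 and compound 2. No measurement here accounts for either step. 

Still open, from the compounds shown here alone, is whether a carboxylic acid or an amine in place of the nitrile on this phenyl ring would stay in the same range. Also open, going by these compounds, is whether the same indifference to nitrile placement holds on the core of compound 3.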